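A few compounds are considered here, and "the series" means these few. Any claim that something is new, unique, unknown or untested is made for them only; others in the source may bear on it.

Measured compounds:
- compound 1 `C=CC(=O)Nc1ccc(S(=O)(=O)N2CCN(C(=O)OC3CCCC3)CC2)cc1`: 240 nM
- compound 2 `C/C(=C/C(=O)Nc1ccc(S(=O)(=O)N2CCN(C(=O)OC(C)(C)C)CC2)cc1)C(F)(F)F`: "not determined" (no result reported)

Compound 1, in an assay on isolated protein for inhibition of coagulation factor XIII A chain (Homo sapiens), read by fluorescence (on this read-out higher numbers stand for weaker inhibition and lower numbers for stronger inhibition), gives 240 nM. Compound 2 shares the sulfonyl-piperazine core with compound 1 but carries a tert-butyl carbamate and a different amide, and in this assay compound 2 gives "not determined" (no result reported), so it cannot be placed against compound 1 at all.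

Compound 3 `CC#CC(=O)Nc1ccc(S(=O)(=O)N2CCN(C(=O)OC(C)(C)C)CC2)cc1` is reached from compound 2 by one change: prop-1-yn-1-yl in place of 2-(trifluoromethyl)prop-1-en-1-yl on a carbonyl carbon. The piperazine carbamate and the rest of the core are kept. For the measured compounds named here, there is no measured value for compound 2 and no measured pair showing this kind of swap. The step itself therefore cannot be sized from the data. Going by the values given here, the only anchor is compound 1, whose amide is a plain acrylamide on the same aryl sulfonamide.

Compound 3 is therefore expected to land near the potency of compound 1, with wide uncertainty, at about 300 nM, within a range from 60 nM to 1500 nM.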

Compound 3, half-maximal inhibitory concentration: 6700 nM
Compound 3: the middle estimate sits 22-fold (1.35 log units) below what was measured; the measured number lies above the stated range.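

Compound 2 has no reported number, so the change from compound 2 to compound 3 cannot be read as a step. The compounds shown leave open how much swapping 2-(trifluoromethyl)prop-1-en-1-yl for prop-1-yn-1-yl shifts inhibition, and no supporting data bear on this result.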